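This account rests on a few compounds, and the source may have more. Where it says the series, first, only, none or still open, it means among the compounds named here.

Series notes. Compound 3 `O=c1c2cccnc2sn1-c1ccc(Br)cc1` gives 4430 nM in an assay for inhibition of histone acetyltransferase KAT2B (Homo sapiens), read by fluorescence; a lower number here means a stronger inhibitor, a higher number a weaker inhibitor; compound 2 `O=c1c2cccnc2sn1-c1ccc([N+](=O)[O-])cc1` gives 4100 nM and compound 1 `O=c1c2cc([N+](=O)[O-])cnc2sn1-c1ccc(Br)cc1` gives 4910 nM, so compound 3 has the second highest of the three numbers, with none of the gaps beyond the scatter. Compound 4 `Cc1ccc(-n2sc3ncccc3c2=O)cc1` carries methyl in place of bromo on an aromatic carbon. Among the measured compounds shown here, two measured steps bear on this: the exchange at the same kind of position, a 1.1-fold higher number from compound 2 to compound 3 (0.03 log units; within the scatter), and the nitro-to-hydrogen change, a 1.1-fold lower number from compound 1 to compound 3 (0.04 log units; within the scatter). Both left this assay unchanged beyond the scatter, so the exchange of bromo for methyl is expected to give no step beyond the scatter either, a 1.0-fold higher number from compound 3 to compound 4 (0.01 log units; within the scatter). Compound 4 is therefore estimated at 4500 nM, within 2200 nM to 9500 nM.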

Compound 4, half-maximal inhibitory concentration: 4630 nM
Compound 4: the middle estimate sits 1.0-fold (0.01 log units) below what was measured, within the range that was stated.
By their numbers in this assay, from the lowest: compounds 2, 3, 4 and 1 (each within the scatter of the next).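

On the aromatic carbon para to a large group, methyl now stands with bromo and nitro as a third group that this assay does not separate (a 1.0-fold higher number from compound 3 to compound 4 (0.02 log units; within the scatter); a 1.1-fold higher number from compound 2 to compound 4 (0.05 log units; within the scatter)). The earlier exchange at this place involved only bromo and nitro, whereas compound 4 extends the flat result to a carbon group. No measured evidence bears on this flat result.

As far as these compounds go, whether an amine, a carboxylic acid or a longer chain at this place would move the number remains open. So does the effect of any group on the shared core other than the nitro of compound 1.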